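The source may hold more compounds than are shown below. What is called first, only, known or untested is meant among the compounds shown, and "the series" means these compounds.

Measured so far:
compound 1 `O=C(Nc1ccccc1)c1cc2n(n1)CCCN(C(=O)c1occc1C(F)(F)F)C2` — 30000 nM
compound 2 `Cc1coc(C(=O)N2CCCn3nc(C(=O)Nc4ccccc4)cc3C2)c1` — "not determined" (no result reported)
compound 3 `Cc1ccccc1NC(=O)c1cc2n(n1)CCCN(C(=O)c1occc1C)C2` — 1100 nM

In an ADME assay on BEAS-2B cells (Homo sapiens) for cytotoxicity, read by fluorescence, with a stated time of 48 h (on this read-out lower numbers stand for higher toxicity in this test and higher numbers for lower toxicity in this test), compound 3 gives 1100 nM, the lowest of the two numbers available; compound 1 sits a long way higher at 30000 nM, a gap beyond the scatter, and compound 2 has no number at all. Compound 4 `Cc1ccoc1C(=O)N1CCCn2nc(C(=O)Nc3ccncn3)cc2C1` is not yet measured. It differs from compound 3 in one place: pyrimidin-4-yl in place of 2-methylphenyl on an amide-type nitrogen. Among the measured compounds shown here, no comparable step between two measured compounds exists in this set, so the expectation rests on compound 3 alone. For the measured compounds named here, a move upward of moderate size is expected for compound 4, as a 4.5-fold higher number from compound 3 to compound 4 (0.66 log units; beyond the scatter), since the only other number in this assay, compound 1 at 30000 nM, lies well above. Compound 4 is estimated at 5000 nM, within a range of 1500 nM to 20000 nM.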

Compound 4, half-maximal cytotoxic concentration: 16600 nM
The estimate for compound 4 lay 3.3-fold (0.52 log units) below the measured number; measured number inside the range.
By their numbers in this assay, from the lowest: compound 3; then compounds 4 and 1 (each within the scatter of the next).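

In this assay the group on the amide-type nitrogen proves able to shift the read-out: pyrimidin-4-yl in place of 2-methylphenyl gives a 15-fold higher number from compound 3 to compound 4 (1.18 log units; beyond the scatter) as a large change. Among the compounds shown here, this is the only one-place step available, and compounds 1 and 3 alone could not isolate this nitrogen's substituent. No measurement shown bears on what lies behind the step.

From the compounds shown here alone, the change removes the methyl and brings in two ring nitrogens together, so their separate contributions remain open. Going by these compounds, how a pyridin-3-yl or cyclohexyl group on this nitrogen would read is also open.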